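A few compounds are considered here, and "the series" means these few. Any claim that something is new, unique, unknown or untested is made for them only; others in the source may bear on it.

Measured in a functional assay on A549 cells (Homo sapiens) for antiproliferative activity, read by MTT assay, with a stated time of 72 h; a lower number here means a stronger inhibitor, a higher number a weaker inhibitor:
compound 1 `CNC(=O)c1cc(Oc2ccc(NC(=O)c3cc4cccnc4n(-c4ccccc4)c3=O)cc2)ccn1`, 200 nM
compound 2 `CNC(=O)c1cc(Oc2ccc(NC(=O)c3cc4cccnc4n(-c4ccccc4F)c3=O)cc2)ccn1`, 610 nM
compound 3 `CNC(=O)c1cc(Oc2ccc(NC(=O)c3cc4cccnc4n(-c4ccc(Br)cc4)c3=O)cc2)ccn1`, 1050 nM

For the measured compounds named here, compound 3 gives the highest of the three numbers, but only the step of a 5.3-fold higher number from compound 1 to compound 3 (0.72 log units; beyond the scatter) lies beyond the scatter, while the step of a 1.7-fold higher number from compound 2 to compound 3 (0.24 log units; within the scatter) lies within it. Compound 4 `CNC(=O)c1cc(Oc2ccc(NC(=O)c3cc4cccnc4n(-c4ccc(OC)cc4)c3=O)cc2)ccn1` differs from compound 3 by one change: methoxy in place of bromo on an aromatic carbon. Going by the values given here, no measured pair exchanges one group for another at this position of the ring on the aromatic nitrogen; the measured steps only replace hydrogen there, as in a 5.3-fold higher number from compound 1 to compound 3 (0.72 log units; beyond the scatter) and, at another position, a 3.1-fold higher number from compound 1 to compound 2 (0.48 log units; beyond the scatter). Both substituted rings gave higher numbers than the bare ring of compound 1, so the methoxy-bearing ring of compound 4 is expected to stay in the region of compound 3 and compound 2 rather than return to the number of compound 1. The expected step in this assay is therefore a 1.5-fold lower number from compound 3 to compound 4 (0.18 log units; within the scatter), a change that does not exceed the scatter. Compound 4 is estimated at 700 nM, within a range from 250 nM to 2000 nM.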

Compound 4, half-maximal inhibitory concentration: 3110 nM
Estimate against measurement, compound 4: 4.4-fold (0.65 log units) below, and the stated range ends below it.
By their numbers in this assay, from the lowest: compound 1; then compounds 2 and 3 (each within the scatter of the next); then compound 4.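

In this assay, for the compounds shown here, the earlier compounds showed only that a group at this position of the ring on the aromatic nitrogen gave a higher number than hydrogen, but a 3.0-fold higher number from compound 3 to compound 4 (0.47 log units; beyond the scatter) shows that the choice of group matters there as well. The 4-methoxyphenyl ring also separates from the 2-fluorophenyl ring in a 5.1-fold higher number from compound 2 to compound 4 (0.71 log units; beyond the scatter) and, with a 16-fold higher number from compound 1 to compound 4 (1.19 log units; beyond the scatter) as the largest step in the set, all three substituted rings stand above the bare ring of compound 1, with no compound shown going against this. Nothing available explains why methoxy gives a higher number than bromo here.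

Going by these compounds, it remains open whether any group at this position can match hydrogen, for instance an amine, a carboxylic acid or a chloro group. On these data alone, it is also open whether methoxy would behave in the same way at the ring position that carries fluoro in compound 2.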